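The source may hold more compounds than are shown below. What is called first, only, known or untested is meant among the compounds shown, and "the series" means these compounds.

Measured compounds:
compound 1 `Nc1ccc(NC(=O)c2c(O)c3cccnc3n(-c3ccccc3)c2=O)cc1` gives -5.5%
compound 2 `Cc1cccc(NC(=O)c2c(O)c3cccnc3n(-c3ccccc3)c2=O)c1` gives 14.2%
compound 3 `O=C(Nc1cccc(Cl)c1)c1c(O)c2cccnc2n(-c2ccccc2)c1=O` gives 7.6%

These three compounds share one core and were all tested in a functional assay on the whole organism for inhibition, with Rattus norvegicus as the target, read by paw edema, at a dose of 100 mg/kg by the oral route; on this read-out lower numbers stand for less inhibition and higher numbers for more inhibition at the one dose given (going by the name of the read-out). Among the three numbers compound 3 stands second highest: it lies within the scatter of compound 2, since a number 6.6 percentage points lower from compound 2 to compound 3 (within the scatter), and beyond the scatter above compound 1, since a number 13.1 percentage points higher from compound 1 to compound 3 (beyond the scatter). Compound 4 `O=C(Nc1nccs1)c1c(O)c2cccnc2n(-c2ccccc2)c1=O` differs from compound 3 in one place: 1,3-thiazol-2-yl in place of 3-chlorophenyl on an amide-type nitrogen. Among the measured compounds shown here, no measured step exchanges the 3-chlorophenyl for a group of this kind, so the measured steps bear on it only loosely. They are the two replacements of 4-aminophenyl on the amide-type nitrogen, a number 19.7 percentage points higher from compound 1 to compound 2 (beyond the scatter) and a number 13.1 percentage points higher from compound 1 to compound 3 (beyond the scatter), both modest, and the exchange of chloro for methyl, a number 6.6 percentage points lower from compound 2 to compound 3 (within the scatter), which stays within the scatter. Changing the group on the amide-type nitrogen has so far shifted the read-out modestly at most. For compound 4 a step of about a number 2.4 percentage points higher from compound 3 to compound 4 (within the scatter) is expected, hardly beyond the scatter. Compound 4 is therefore estimated at 10%, with a range from -10% to 30%.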

Compound 4, a percentage reported as inhibition, in the whole organism at one dose (the size of the read-out at that dose, not a potency): 4.6%
Beside the measured number, compound 4's estimate is 5.4 percentage points above it; low and high end bracket the measured number.
By their numbers in this assay, from the lowest: compound 1; then compounds 4, 3 and 2 (each within the scatter of the next).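

In this assay the 1,3-thiazol-2-yl group, a five-membered aromatic ring with 2 hetero atoms, gives a number 3 percentage points lower from compound 3 to compound 4 (within the scatter) and a number 9.6 percentage points lower from compound 2 to compound 4 (within the scatter) and so cannot be told apart from the 3-chlorophenyl or 3-methylphenyl group on the amide-type nitrogen. This position therefore accepts a smaller ring containing nitrogen and sulfur without a clear change in the read-out, while the 4-aminophenyl compound remains apart, with a number 10.1 percentage points higher from compound 1 to compound 4 (beyond the scatter) as a modest step. No measurement shown here explains why these groups read alike.

As far as these compounds go, it remains open whether a non-aromatic group on this nitrogen, such as cyclohexyl or a longer alkyl chain, would fit the same picture. A carboxylic acid on the phenyl ring of the amide is equally untested among the compounds shown.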